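The source may hold more compounds than are shown below. What is called first, only, known or untested is meant among the compounds shown, and "the series" means these compounds.

Measured compounds: compound 1 `COc1ccc(/C=C/C(=O)OC[C@@H](OCc2ccccc2)[C@H]2OC(=O)C=C[C@H]2OCc2ccccc2)cc1` and compound 2 `CC(=O)OC[C@@H](OCc1ccccc1)[C@H]1OC(=O)C=C[C@H]1OCc1ccccc1`.

In a functional assay on K562 cells (Homo sapiens) for antiproliferative activity, read by MTT assay, with a stated time of 6 days (a lower number here means a stronger inhibitor, a higher number a weaker inhibitor), compound 1 gives 430 nM. In this assay, among the compounds with values here, compound 2 gives 880 nM, which is the higher of the two numbers; the only step known, a 2.0-fold higher number from compound 1 to compound 2 (0.31 log units; beyond the scatter), separates them. Compound 3 `O=C1C=C[C@@H](OCc2ccccc2)[C@@H]([C@@H](CO)OCc2ccccc2)O1` has not yet been measured. The change from compound 2 to compound 3 is hydrogen in place of acetyl on an oxygen on a saturated carbon, so the ester at that position is removed altogether and a free hydroxymethyl remains. Within the data shown here, no measured step exchanges an acyl group for hydrogen at this oxygen; the only guide is the trend from compound 1 to compound 2, where shortening the acyl group gave a modest rise in the number. On that basis a further modest rise in this assay for compound 3 is expected, though the uncertainty is wide. The estimate for compound 3 is 1500 nM with a range from 500 nM to 5000 nM. The expected step of a 1.7-fold higher number from compound 2 to compound 3 (0.23 log units; within the scatter) thus points toward a weaker inhibitor.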

Compound 3, half-maximal inhibitory concentration: 1420 nM
Compound 3: middle estimate off by 1.1-fold (0.02 log units), on the high side; the range from low to high includes it.
By their numbers in this assay, from the lowest: compound 1; then compounds 2 and 3 (each within the scatter of the next).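

In this assay the acyl group on this oxygen can be lost entirely with the number staying in the same range: a 1.6-fold higher number from compound 2 to compound 3 (0.21 log units; within the scatter) separates the acetoxymethyl and hydroxymethyl forms, so the two cannot be told apart. The free hydroxy compound differs clearly only from the compound carrying the larger acyl group, with a 3.3-fold higher number from compound 1 to compound 3 (0.52 log units; beyond the scatter) marking that gap. At this position, then, the acetyl ester shows no measurable gain over hydrogen, and only the (2-(4-methoxyphenyl)ethenyl)carbonyl group stands apart from the free hydroxy compound. On these data alone, it remains open how an amine or a carboxylic acid in place of the hydroxy group would read here, and whether a longer acyl chain without the aromatic ring would track acetyl or the larger ester. Nothing given here accounts for these numbers.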